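Aryl swap on a sulfonamide series, outlook for compound 3

The compounds below may be only part of what the source reports. "The series", "measured", "known", "first", "only" and "open" are said of these compounds alone.

Measured so far:
compound 1 `COc1ccc(S(=O)(=O)N2CCc3cccc(-c4ccc(F)nc4)c32)cc1` — 151 nM
compound 2 `COc1ccc(S(=O)(=O)n2ccc3cccc(-c4ccc(F)cc4)c32)cc1` — 202 nM

In a functional assay on KB-VIN10 cells (Homo sapiens) for inhibition, with a stated time of 72 h (on this read-out lower numbers stand for stronger inhibition and higher numbers for weaker inhibition), compound 1 gives 151 nM, the lowest of the two numbers recorded so far, while compound 2 gives 202 nM; these two lie within the scatter of each other, so nothing separates them. Among the compounds with values here, no step between measured compounds that differ in one place is at hand, so the move to compound 3 `COc1ccc(S(=O)(=O)N2CCc3cccc(-c4ccc(N)cc4)c32)cc1` rests on the structural change alone: 4-aminophenyl in place of 6-fluoropyridin-3-yl on an aromatic carbon. The group that leaves and the group that enters are matched in heavy-atom size; the entering group carries a hydrogen-bond donor that the leaving group lacks, and the ring changes from one with a hetero atom to one of carbon only. Without a related step to lean on, the expected step of a 1.3-fold higher number from compound 1 to compound 3 (0.12 log units; within the scatter) is small and of uncertain direction, most likely no change beyond the scatter. Compound 3 is therefore expected to land at 200 nM, within 60 nM to 700 nM.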

Compound 3, half-maximal inhibitory concentration: 262 nM
Compound 3: the middle estimate sits 1.3-fold (0.12 log units) below what was measured, within the range that was stated.
By their numbers in this assay, from the lowest: compounds 1, 2 and 3 (each within the scatter of the next).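

In this assay, putting 4-aminophenyl in place of 6-fluoropyridin-3-yl on this aromatic carbon gives a 1.7-fold higher number from compound 1 to compound 3 (0.24 log units; within the scatter), so the position accepts a ring of carbon only carrying a hydrogen-bond donor, with no step beyond the scatter. Within the data shown here, this is the only one-place comparison so far, and it shows that the ring hetero atom and the fluorine of compound 1 can both leave without a step beyond the scatter. The hetero atom, the fluorine and the amine all change together in this single step, and their separate shares cannot be read from it. No measured property of either group bears on this result.

Open, going by these compounds, is whether the amine itself matters here: a hydroxyl, methoxy or dimethylamino group in its place on the same ring would test this. Also open, on these data alone, is whether a carboxylic acid or a longer chain at this position would stay within the scatter of compound 1.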